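A few compounds are considered here, and "the series" means these few. Any claim that something is new, unique, unknown or untested is made for them only; others in the source may bear on it.

In a functional assay on B16-F10 cells (Mus musculus) for antiproliferative activity, read by MTT assay, with a stated time of 48 h (a higher number here means a weaker inhibitor, a lower number a stronger inhibitor), three compounds sharing much of one core have been measured. Compound 1 `COc1ccc(/C=C/c2cc(OC)cc(OC)c2/C=C/C(=O)c2cccc(OC)c2)cc1` gives 4.3 ug/mL, compound 2 `CCCCCCOc1ccc(C(=O)/C=C/c2c(/C=C/c3ccc(OC)cc3)cc(OC)cc2OC)cc1` gives 10.4 ug/mL and compound 3 `COc1ccc(/C=C/c2cc(OC)cc(OC)c2/C=C/C(=O)c2ccc(N)cc2)cc1` gives 2.8 ug/mL. Compound 2 has the highest number of the three, and the values of the other two both lie beyond the scatter from it. Compound 4 `COc1ccc(/C=C/c2cc(OC)cc(OC)c2/C=C/C(=O)c2ccc(Cl)cc2)cc1` has not yet been measured. It differs from compound 2 in one group: chloro in place of hexyloxy on an aromatic carbon, para to a large group.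

For the measured compounds named here, two measured steps bear on this change. The closer is a 3.7-fold lower number from compound 2 to compound 3 (0.57 log units; beyond the scatter), where hexyloxy also leaves, with amino in its place on an aromatic carbon. The other, a 1.5-fold lower number from compound 1 to compound 3 (0.19 log units; within the scatter), shows that these two compounds without the hexyloxy do not separate. Going by the values given here, no chloro compound has been measured, so the size of the step rests on these comparisons alone. A modest step towards a lower number is expected in this assay, similar to or a little smaller than the one seen with amino, and the estimated step is a 2.3-fold lower number from compound 2 to compound 4 (0.36 log units; beyond the scatter). Compound 4 is estimated at 4.5 ug/mL, with an expected range from 2.2 ug/mL to 9 ug/mL.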

Compound 4, half-maximal inhibitory concentration: 4.9 ug/mL
Estimate against measurement, compound 4: 1.1-fold (0.04 log units) below, and the stated range covers the measured number.
By their numbers in this assay, from the lowest: compounds 3, 1 and 4 (each within the scatter of the next); then compound 2.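

In this assay, the change from hexyloxy to chloro, on an aromatic carbon para to a large group, gives a 2.1-fold lower number from compound 2 to compound 4 (0.33 log units; beyond the scatter) and so shows that a lower number at this position does not depend on the amino group of compound 3. Chloro and amino do not separate here, with a 1.8-fold higher number from compound 3 to compound 4 (0.24 log units; within the scatter) as their step, and the change of the whole aryl group gives a 1.1-fold higher number from compound 1 to compound 4 (0.06 log units; within the scatter) without separating those two compounds either, so that among the four compounds only compound 2, the one with hexyloxy, stands apart from the rest of its series. No measured property of these groups is at hand to account for this, and the reason for the separation stays unexplained.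

The compounds shown leave open whether the higher number of compound 2 belongs to hexyloxy as a long chain or to alkoxy groups at this position in general, which a shorter ethoxy or butoxy chain at the same carbon would help to settle. They also leave open whether a carboxylic acid, a nitrile or a plain hydrogen there would stay with compounds 1, 3 and 4 or move away from them.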